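Lengthening the cyano-bearing chain of compound 2

This account rests on a few compounds, and the source may have more. Where it says the series, first, only, none or still open, it means among the compounds named here.

Compound 2 `C=CCc1cc(C(C)=O)c(O)cc1OCC#N` is tested in an assay on isolated protein for inhibition of leukotriene B4 receptor 1 (Homo sapiens), tested at 10 uM (a lower number here means less inhibition, a higher number more inhibition at the concentration tested (going by the name of the read-out)), and gives 20%, the lower of the two numbers in hand. Compound 1 `CC(=O)c1cc(CO)c(OCCCCCCC#N)cc1O` gives 40%, a gap beyond the usual scatter, but the two compounds differ in more than one place, so only their two values can be compared. Compound 3 `C=CCc1cc(C(C)=O)c(O)cc1OCCCCCC#N` carries 4-cyanobutyl in place of cyano on a saturated chain carbon bound to an oxygen on an aromatic ring relative to compound 2. For the measured compounds named here, no single-change step between measured compounds exists here, yet a moderate rise is expected, the step of a number 15 percentage points higher from compound 2 to compound 3 (beyond the scatter) being the estimate. Compound 3 is accordingly expected to give 35%, with a range from 15% to 55%.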

Compound 3, a percentage reported as inhibition, at one concentration (the size of the read-out at that concentration, not a potency): 81%
Compound 3: middle estimate off by 46 percentage points, on the low side; the measured number lies above the stated range.
By their numbers in this assay, from the lowest: compound 2; then compound 1; then compound 3.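

Placing 4-cyanobutyl in place of cyano on a saturated chain carbon bound to an oxygen on an aromatic ring gives, in this assay, a number 61 percentage points higher from compound 2 to compound 3 (beyond the scatter). This single change shows that the position accepts the longer nitrile-bearing chain and that the inhibition responds strongly to its length, which compound 1, differing in more than one place, could not show. Nothing at hand explains the size of this step. From the compounds shown here alone, whether a shorter chain or a longer chain would match compound 3 remains open. So does whether the nitrile is needed at the chain end, or whether an amine or a carboxylic acid could stand there instead.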